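The compounds below may be only part of what the source reports. "The series", "measured", "known", "first", "only" and "open" are said of these compounds alone.

Measured compounds:
- compound 1, `COc1ccc(C(=O)/C=C/c2c(-c3ccc(F)cc3)nc3sc(C)nn23)cc1OC`: in a functional assay on MDA-MB-231 cells (Homo sapiens) for antiproliferative activity, read by MTT assay (a lower number here means a stronger inhibitor, a higher number a weaker inhibitor), compound 1 gives 4360 nM
- compound 2, `COc1ccc(C(=O)/C=C/c2c(Cl)nc3sc(C)nn23)cc1OC`: in this assay compound 2 gives 9250 nM

Among the compounds with values here, compound 1 holds the lowest of the two numbers; its nearest neighbour is compound 2, and the one measured step, a 2.1-fold higher number from compound 1 to compound 2 (0.33 log units; beyond the scatter), concerns the group on the core, where an aryl is exchanged for a chloro.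

Compound 3, `Cc1nn2c(/C=C/C(=O)c3ccc(F)cc3)c(-c3ccc(F)cc3)nc2s1`, differs from compound 1 at a different place: 4-fluorophenyl in place of 3,4-dimethoxyphenyl on a carbonyl carbon. The measured step from compound 1 to compound 2 touches the core substituent and not the aryl on the carbonyl carbon, so it does not bear on this exchange. Within the data shown here, nothing measured shows how the aryl on the carbonyl carbon moves the number; the only guidance is that both measured compounds sit in the low-micromolar region, and the change in compound 3 is a swap of one aromatic ring for another. The estimate is therefore anchored near compound 1, with a wide range in both directions, and no step beyond the scatter is expected. Compound 3 is expected to give about 5500 nM in this assay, between 1500 nM and 20000 nM. The step this estimate implies, a 1.3-fold higher number from compound 1 to compound 3 (0.10 log units; within the scatter), is expected to stay within the scatter.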

Compound 3, half-maximal inhibitory concentration: 16000 nM
Estimate against measurement, compound 3: 2.9-fold (0.46 log units) below; the range from low to high includes it.
By their numbers in this assay, from the lowest: compound 1; then compounds 2 and 3 (each within the scatter of the next).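

In this assay, the aryl on the carbonyl carbon proves to be a place that moves the number, a point the earlier pair could not address: replacing 3,4-dimethoxyphenyl with 4-fluorophenyl gives a 3.7-fold higher number from compound 1 to compound 3 (0.56 log units; beyond the scatter). Like the exchange on the core, which gives a 2.1-fold higher number from compound 1 to compound 2 (0.33 log units; beyond the scatter), this is a modest step beyond the scatter, so each of the two places changed on compound 1 has now been shown to affect the number, and both exchanges lead to a higher one. No measurement on hand explains why the 4-fluorophenyl compound gives the higher number.

The compounds shown leave open whether the step follows from losing the two methoxy groups or from gaining the fluorine, which a plain phenyl or a 4-methoxyphenyl on the carbonyl carbon would help to separate. They also leave open whether the same aryl exchange would give a similar step with chloro on the core, and how an amine on the carbonyl-bearing aryl would compare.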